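Adding a Hydroxy Group to the Piperazine Aryl Ring

The source may hold more compounds than are shown below. What is called first, only, known or untested is meant among the compounds shown, and "the series" means these compounds.

Three compounds have been measured in a functional assay on KK-47 cells for antiproliferative activity against KK-47 cell line (Homo sapiens), read by MTT assay, with a stated time of 48 h; a lower number here means a stronger inhibitor, a higher number a weaker inhibitor:

Compound 1, `COc1cc(O)ccc1N1CCN(CC(O)COc2cccc3ccccc23)CC1`: 11800 nM
Compound 2, `COc1cc(O)ccc1N1CCN(CC(O)COc2ccc(O)c3ccccc23)CC1`: > 50000 nM
Compound 3, `Oc1ccccc1N1CCN(CC(O)COc2ccc(O)c3ccccc23)CC1`: 33000 nM

The value of compound 2 is a limit of the assay, not a number. Compound 2 differs from compound 1 by hydroxy in place of hydrogen on an aromatic carbon, and that change gave an at least 4.2-fold higher number from compound 1 to compound 2 (0.62 log units; beyond the scatter). Compound 3 differs from compound 2 in the group on the ring nitrogen, and that change gave an at least 1.5-fold lower number from compound 2 to compound 3 (0.18 log units; that floor lies within the scatter). Of the two plain numbers, compound 3 carries the higher one, and its gap to compound 1 lies beyond the scatter. How the core of compound 3 differs from the core of compound 1 is not broken down here.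

Compound 4, `Oc1ccc(N2CCN(CC(O)COc3ccc(O)c4ccccc34)CC2)c(O)c1`, has not yet been measured. It differs from compound 3 by hydroxy in place of hydrogen on an aromatic carbon. Among the measured compounds shown here, this is the same kind of change as the one from compound 1 to compound 2, not the same change: there the hydroxy entered a ring that is part of a fused system of two rings, ortho to a fused ring and meta to a fused ring, whereas here it enters a six-membered ring of carbon only, meta to a hydroxy group; in both cases the new group sits para to a large group.

Starting from the value of compound 3, 33000 nM, and taking the earlier hydroxy step an at least 4.2-fold higher number from compound 1 to compound 2 (0.62 log units; beyond the scatter) as a guide, the change to compound 4 is expected to give a 1.8-fold higher number from compound 3 to compound 4 (0.26 log units; within the scatter). The value of compound 4 is therefore estimated at 60000 nM, most likely between 25000 nM and 150000 nM. Since the earlier step ended at the limit of > 50000 nM in this assay, at which 1 of the 3 values shown sits, the result for compound 4 may again be reported only as a limit.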

Compound 4, half-maximal inhibitory concentration: 17900 nM
The estimate for compound 4 lay 3.4-fold (0.53 log units) above the measured number; measured number outside the range, below it.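

In this assay, hydroxy in place of hydrogen on an aromatic carbon does not carry over from one core to another as a fixed step: the same change on two cores in this assay, an at least 4.2-fold higher number (0.62 log units; beyond the scatter) from compound 1 to compound 2 and a 1.8-fold lower number (0.27 log units; within the scatter) from compound 3 to compound 4, at least 7.8-fold (0.89 log units) apart, beyond the scatter of two such steps

Read alone, the new step, a 1.8-fold lower number from compound 3 to compound 4 (0.27 log units; within the scatter), shows no clear difference, whereas hydrogen in place of methyl on an oxygen on an aromatic ring, an at least 2.7-fold lower number from compound 2 to compound 4 (0.44 log units; beyond the scatter), is a clear move toward a stronger inhibitor. On these data alone, the value of compound 2, > 50000 nM, is a limit of the assay and not a number, so the true size of every step that starts or ends at compound 2 stays unknown, and a single pair on each core cannot show whether the core itself or the different place of the new hydroxy sets the two steps apart.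

The compounds shown leave open whether an amine or a fluorine in place of the new hydroxy on the 2,4-dihydroxyphenyl group would give a step as small as this one. They also leave open which of the two hydroxy steps, if either, a third core would follow.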